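The source may report more compounds than this note shows. Statements on the series, on what has been measured and on what is new or still open speak of the compounds shown alone.

The measured compounds in a physicochemical assay for solubility, read by HPLC, in simulated intestinal fluid, with a stated time of 16 h, at pH 6.5; a higher number here means a more soluble compound, a lower number a less soluble compound:

Compound 1, `CNC(=O)c1cc(C(=O)N[C@H]2CC[C@H](O)CC2)n([C@@H](C)c2ccc(Cl)cc2)n1`, gives 102 ug/mL.
Compound 2, `CCC(=O)c1c[nH]c(C(=O)NC)c1`, gives 13 ug/mL.
Compound 3, `CNC(=O)c1cc(C(=O)N[C@H]2CC[C@H](O)CC2)c([C@@H](C)c2ccccc2Cl)o1`, gives > 1000 ug/mL.

Compound 3 stands at the limit of > 1000 ug/mL in this assay, at which 1 of the 3 values shown sits, so for compound 3 the assay reports only a limit, not a number. Compound 1 and compound 2 each give a plain number, and both are lower than the limit at which compound 3 sits.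

Compound 4, `CNC(=O)c1cc(C(=O)N[C@H]2CC[C@H](O)CC2)c([C@@H](C)c2ccc(C)cc2)o1`, has not yet been measured in this assay. It differs from compound 3 in one place: 4-methylphenyl in place of 2-chlorophenyl on a saturated chain carbon bound to an aromatic carbon and a saturated chain carbon. The shared core of compound 3 and compound 4, with its two amide groups and its hydroxylated ring, is untouched; only the aromatic ring on the saturated chain carbon changes.

Among the measured compounds shown here, no measured pair in this set shows this kind of change, so the size of the step of an at least 1.4-fold lower number from compound 3 to compound 4 (0.15 log units; that floor lies within the scatter) can only be expected to be small, not beyond the usual scatter, and in either direction. For compound 4 the estimate is 700 ug/mL, with a range from 250 ug/mL to 1000 ug/mL.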

Compound 4, solubility: > 1000 ug/mL
Compound 4: only a limit was reported; the forecaster's own chance of this, stated with the estimate: 45%; middle value at least 1.4-fold (0.15 log units) from the limit.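

In this assay, compound 3 and compound 4 each give only a limit, not a number, so no step between them can be read: the limit of > 1000 ug/mL in this assay, at which 2 of the 4 values shown sit.

The compounds shown leave open whether 4-methylphenyl in place of 2-chlorophenyl changes the solubility at all, and in which direction.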